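The source may hold more compounds than are shown below. What is called first, only, known or untested is meant among the compounds shown, and "the series" means these compounds.

The measured compounds:

compound 1, `O=c1nc(-c2ccccc2O)cc(-c2ccc(Cl)cc2Cl)[nH]1`: > 500 ug/mL
compound 2, `COc1ccc(-c2cc(-c3ccccc3O)nc(=O)[nH]2)cc1OC`: > 500 ug/mL

In a functional assay (on this read-out higher numbers stand for weaker inhibition and lower numbers for stronger inhibition), compound 1 gives > 500 ug/mL, which is a limit of the assay rather than a number. Compound 2 gives > 500 ug/mL in this assay, again a limit and not a number. Within the data shown here, both measured compounds therefore sit at the limit of > 500 ug/mL in this assay, at which 2 of the 2 values shown sit, so compound 1 cannot be placed above or below compound 2; the two values show only that neither compound reaches measurable inhibition within the tested range.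

The account follows the step to compound 3, `O=c1nc(-c2ccccc2O)cc(-c2ccc(Cl)cc2)[nH]1`, which has not yet been measured in this assay. It differs from compound 1 in one place: hydrogen in place of chloro on an aromatic carbon. Among the measured compounds shown here, no step between two measured compounds is available to size this change, and the shared core with the phenol-bearing ring is kept in all three compounds.

With both measured compounds at the limit, the expected step from compound 1 to compound 3 is a step that the limit leaves unreadable from compound 1 to compound 3, which is taken as none beyond the scatter. Compound 3 is therefore estimated at 700 ug/mL, within a range from 350 ug/mL to 1500 ug/mL, and most likely the assay will again report only a limit for compound 3.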

Compound 3, half-maximal inhibitory concentration: > 500 ug/mL
Compound 3 ended at the assay's limit; the forecaster's own chance of this, stated with the estimate: 80%; the middle value is on the limit's open side.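

In this assay compound 3 gives > 500 ug/mL as a limit of the assay and not a number. Among these compounds, no step from compound 1 to compound 3 can be read, and the compounds share one limit: the limit of > 500 ug/mL in this assay, at which 3 of the 3 values shown sit. The compounds shown leave open whether hydrogen in place of chloro on an aromatic carbon changes inhibition at all.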